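Rhodanine-acetamide series: amide substituent variation and a tetrazole replacement

The source may hold more compounds than are shown below. What is called first, only, known or untested is meant among the compounds shown, and "the series" means these compounds.

Measured so far in a functional assay on K562 cells (Homo sapiens) for cytotoxicity, read by MTT assay, with a stated time of 72 h; on this read-out lower numbers stand for stronger inhibition and higher numbers for weaker inhibition:
compound 1 `N#Cc1ccc(NC(=O)CN2C(=O)/C(=C/c3ccc(-c4ccc(Cl)cc4)o3)SC2=S)cc1` gives 85000 nM;
compound 2 `COc1ccc(CNC(=O)CN2C(=O)/C(=C/c3ccc(-c4ccc(Cl)cc4)o3)SC2=S)cc1` gives 40000 nM;
compound 3 `O=C(CN1C(=O)/C(=C/c2ccc(-c3ccc(Cl)cc3)o2)SC1=S)NCc1ccc(Br)cc1` gives 68000 nM.

All three numbers sit close together. Compound 3 stands second highest of the three; its nearest neighbour is compound 1 (a 1.3-fold lower number from compound 1 to compound 3 (0.10 log units; within the scatter)), and its furthest is compound 2 (a 1.7-fold higher number from compound 2 to compound 3 (0.23 log units; within the scatter)), both within the scatter. Among the measured compounds shown here, the only step read as beyond the scatter is a 2.1-fold lower number from compound 1 to compound 2 (0.33 log units; beyond the scatter), and it is modest.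

The next compound to be measured is compound 4 `O=C(CN1C(=O)/C(=C/c2ccc(-c3ccc(Cl)cc3)o2)SC1=S)Nc1nnn[nH]1`. Relative to compound 3 the change is 1H-tetrazol-5-yl in place of 4-bromobenzyl on an amide-type nitrogen. For the measured compounds named here, no measured step involves a group of this kind on the amide-type nitrogen; the steps known so far only exchange one carbon-ring substituent for another, and none of them moves the number far. They therefore give no direction for a ring of four hetero atoms entering here, and nothing in the series suggests the shared core changes its behaviour much with the amide substituent. The expected step is accordingly small, possibly none beyond the scatter, with a wide uncertainty.

For compound 4 in this assay the estimate is 90000 nM, with a range from 30000 nM to 250000 nM; this is expected to correspond to a 1.3-fold higher number from compound 3 to compound 4 (0.12 log units; within the scatter).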

Compound 4, half-maximal inhibitory concentration: 52000 nM
Estimate against measurement, compound 4: 1.7-fold (0.24 log units) above; low and high end bracket the measured number.
By their numbers in this assay, from the lowest: compounds 2, 4, 3 and 1 (each within the scatter of the next, the first and the last beyond it).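

In this assay, the 1H-tetrazol-5-yl group on the amide-type nitrogen stays level with all three carbon-ring substituents: a 1.3-fold lower number from compound 3 to compound 4 (0.12 log units; within the scatter), a 1.3-fold higher number from compound 2 to compound 4 (0.11 log units; within the scatter) and a 1.6-fold lower number from compound 1 to compound 4 (0.21 log units; within the scatter). The earlier compounds shown here covered only six-membered aromatic rings of carbon, so this result extends the flat picture at this position to a five-membered aromatic ring with 4 hetero atoms, with hydrogen-bond donor and acceptors counted on the entering group that the 4-bromobenzyl group lacks; the one exception remains the modest step between two carbon-ring compounds, a 2.1-fold lower number from compound 1 to compound 2 (0.33 log units; beyond the scatter). No measurement available here accounts for this insensitivity.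

Going by these compounds, it remains open whether a simple amine, a carboxylic acid or a longer alkyl chain on the amide-type nitrogen would take the number outside this narrow band, or whether it would stay as flat as the substituents seen so far. All four compounds also carry the same shared core, so these data cannot separate how much of the level of the numbers comes from that core and how much from the amide substituent.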